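Amide substituent change from compound 2 to compound 4

The source may report more compounds than this note shows. Statements on the series, on what has been measured and on what is new or still open speak of the compounds shown alone.

Compound 1 `O=C(NC1CCCCC1)c1cc2ccccc2oc1=O`: in an in vitro assay on BTI-TN-5B1-4 cells for inhibition of Amine oxidase [flavin-containing] B (Homo sapiens), read by fluorescence (on this read-out lower numbers stand for stronger inhibition and higher numbers for weaker inhibition), compound 1 gives 500 nM
Compound 2 `NCCNC(=O)c1cc2ccccc2oc1=O`: in this assay compound 2 gives 7680 nM
Compound 3 `O=C(Nc1ccccc1Cc1ccccc1)c1cc2ccccc2oc1=O`: in this assay compound 3 gives 910 nM

Compound 2 stands highest of the three numbers in this assay; compound 3 is nearest to it and compound 1 furthest. Compound 4 `Cc1ccc(NC(=O)c2cc3ccccc3oc2=O)cc1` differs from compound 2 by 4-methylphenyl in place of 2-aminoethyl on an amide-type nitrogen. Among the compounds with values here, the one measured step that bears on this is a 15-fold higher number from compound 1 to compound 2 (1.19 log units; beyond the scatter), which shows how strongly the 2-aminoethyl group raised the number relative to a ring-bearing amide substituent. Compound 3, with an aryl substituent on the same nitrogen, also sits well below compound 2. A lower number is therefore expected for compound 4, with a step of about an 11-fold lower number from compound 2 to compound 4 (1.04 log units; beyond the scatter). Compound 4 is estimated at 700 nM, within 250 nM to 2500 nM.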

Compound 4, half-maximal inhibitory concentration: 710 nM
Estimate against measurement, compound 4: 1.0-fold (0.01 log units) below; low and high end bracket the measured number.
By their numbers in this assay, from the lowest: compounds 1, 4 and 3 (each within the scatter of the next); then compound 2.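

In this assay, 4-methylphenyl on the amide-type nitrogen gives an 11-fold lower number from compound 2 to compound 4 (1.03 log units; beyond the scatter), so a six-membered aromatic ring of carbon only, like the cyclohexyl of compound 1, stands far from 2-aminoethyl at this position. Against cyclohexyl, the same group gives a 1.4-fold higher number from compound 1 to compound 4 (0.15 log units; within the scatter), so these two rings cannot be told apart in this read-out. Nothing available here accounts for either step. Still open, on these data alone, is whether a methoxy group in place of the methyl of 4-methylphenyl would keep the number at this level. Also open, as far as these compounds go, is how a longer chain ending in an amine would compare with 2-aminoethyl.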